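Adding a Second Nitro Group to the Shared Core

A few compounds are considered here, and "the series" means these few. Any claim that something is new, unique, unknown or untested is made for them only; others in the source may bear on it.

Going by the values given here, compound 1 `COc1cc2c(cc1OC)C(=O)/C(=C/c1cc(C)c([N+](=O)[O-])c(C)c1)C2` is the weaker of the two compounds measured so far: in a functional assay on Jurkat cells (Homo sapiens) for antiproliferative activity, read by MTT assay (a lower number here means a stronger inhibitor, a higher number a weaker inhibitor), compound 1 gives 25000 nM, the highest number of the pair. Among the compounds with values here, its nearest neighbour is compound 2 `CCOC(=O)COc1c(C)cc(/C=C2\Cc3cc(OC)c(OC)cc3C2=O)cc1C`, which in this assay gives 2200 nM, and the single step recorded so far is an 11-fold lower number from compound 1 to compound 2 (1.06 log units; beyond the scatter), obtained by placing (ethoxycarbonyl)methoxy in place of nitro on an aromatic carbon. Compound 3 `COc1cc2c(c([N+](=O)[O-])c1OC)C(=O)/C(=C/c1cc(C)c([N+](=O)[O-])c(C)c1)C2` keeps everything in compound 1 and adds one group: nitro in place of hydrogen on an aromatic carbon, ortho to a fused ring and ortho to a methoxy group on the shared core. Within the data shown here, no measured step bears on this particular change, since the only step known touches the other ring. With nothing to point either way, the expectation for this assay is a step of about a 1.3-fold lower number from compound 1 to compound 3 (0.10 log units; within the scatter), that is, nothing beyond the usual scatter. Compound 3 is therefore estimated at 20000 nM, within a range of 6000 nM to 70000 nM.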

Compound 3, half-maximal inhibitory concentration: > 50000 nM
Compound 3: only a limit was reported; the forecaster's own chance of this, stated with the estimate: 15%; at least 2.5-fold (0.39 log units) between middle value and limit.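

This is the first change shown on the shared core: nitro in place of hydrogen, ortho to a fused ring and ortho to a methoxy group, gives an at least 2.0-fold higher number from compound 1 to compound 3 (0.30 log units; that floor lies within the scatter). Thus, in this assay, adding nitro at this position brings no sign of a stronger inhibitor, something the earlier step could not show because it touched only the other ring. The result for compound 3 is a limit and not a number: the limit of > 50000 nM in this assay, at which 1 of the 3 values shown sits.

Going by these compounds, how far compound 3 truly lies from compound 1 stays open, including whether the gap exceeds the usual scatter. Also open, on these data alone, is whether an amine at this same position would behave like nitro, and whether a core nitro group would have the same effect alongside the (ethoxycarbonyl)methoxy group of compound 2.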